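The source may report more compounds than this note shows. Statements on the series, on what has been measured and on what is new or still open speak of the compounds shown alone.

Working notes on the series, read in a toxicity assay on cells (Macrophage, Mus musculus, strain BALB/c) for cytotoxicity, read by MTT assay; a higher number here means a weaker inhibitor, a lower number a stronger inhibitor. Compound 1 (`C=CCOc1cc(OC)c(C(=O)/C=C/c2ccc(F)cc2)c(OCC=C)c1`) gives 13800 nM, compound 2 (`C=CCOc1cc(OC)c(C(=O)/C=C/c2cccc(OC)c2)c(OCC=C)c1`) gives 13100 nM, and compound 3 (`C=CCOc1cc(OC)c(C(=O)/C=C/c2ccccn2)c(OCC=C)c1`) gives 12500 nM. Compound 3 therefore stands level with the other two, separated from neither by more than the scatter.

The next entry is compound 4 (`C=CCOc1cc(OC)c(C(=O)/C=C/c2ccccc2F)c(OCC=C)c1`), with 2-fluorophenyl in place of pyridin-2-yl on a double-bonded chain carbon bound to a double-bonded chain carbon.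

Going by the values given here, three measured steps bear on this change, all exchanges at that same place: a 1.1-fold lower number from compound 1 to compound 3 (0.04 log units; within the scatter), a 1.0-fold lower number from compound 2 to compound 3 (0.02 log units; within the scatter) and a 1.1-fold lower number from compound 1 to compound 2 (0.02 log units; within the scatter). Each lies within the scatter, so 4-fluorophenyl, 3-methoxyphenyl and pyridin-2-yl at this place have so far given values that cannot be told apart. Among the compounds with values here, no measured compound carries 2-fluorophenyl, so that group itself remains untested, and the three compounds make only a small set.

On this evidence, no step beyond the scatter is expected in this assay, and no direction can be assigned. The expected step is a 1.0-fold higher number from compound 3 to compound 4 (0.02 log units; within the scatter). Compound 4 is estimated at 13000 nM, with an expected range of 8000 nM to 20000 nM.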

Compound 4, half-maximal inhibitory concentration: 13300 nM
For compound 4 the middle estimate is 1.0-fold (0.01 log units) below the measured one; the measured number falls inside the stated range.
By their numbers in this assay, from the lowest: compounds 3, 2, 4 and 1 (each within the scatter of the next).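

At the place on a double-bonded chain carbon bound to a double-bonded chain carbon, 2-fluorophenyl falls level with the other three groups in this assay: the steps are a 1.1-fold higher number from compound 3 to compound 4 (0.03 log units; within the scatter), a 1.0-fold higher number from compound 2 to compound 4 (0.01 log units; within the scatter) and a 1.0-fold lower number from compound 1 to compound 4 (0.02 log units; within the scatter). The first of these shows that exchanging pyridin-2-yl, with its ring hetero atom and hydrogen-bond acceptor, for the all-carbon 2-fluorophenyl ring, which counts no hydrogen-bond acceptor, gives no step beyond the scatter, and the last shows the same for 2-fluorophenyl against 4-fluorophenyl. Nothing in hand offers an explanation for why these four values stay level.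

As far as these compounds go, all four groups at this place are six-membered aromatic rings, so it remains open whether an amine, a carboxylic acid or a longer alkyl chain there would stay at this level. The shared core is also constant across the four compounds, which leaves open how far the number would move with a change elsewhere, such as replacing the allyl ethers with a hydroxyl.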